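Adding a chloro to the benzyl of compound 3

The source may hold more compounds than are shown below. What is called first, only, known or untested is meant among the compounds shown, and "the series" means these compounds.

Compound 3 `CC1=C(C(=O)Nc2ccc([N+](=O)[O-])cc2)C(c2ccc(Br)cc2)N=C(SCc2ccccc2)N1` gives 21.1% in a functional assay on the whole organism (artery, strain albino) with Rattus norvegicus as the target, with a stated time of 720 min, at a dose of 10 mg/kg by the oral route (a lower number here means less inhibition, a higher number more inhibition at the dose given (going by the name of the read-out)), the highest of the three numbers, yet compound 1 `CC1=C(C(=O)Nc2ccc(F)cc2)C(c2ccc([N+](=O)[O-])cc2)N=C(SCc2ccccc2Cl)N1` with 13.9% and compound 2 `CC1=C(C(=O)Nc2ccc(F)cc2)C(c2ccc([N+](=O)[O-])cc2)N=C(SCc2cccc(Cl)c2)N1` with 12.9% both lie within the scatter of it. Compound 4 `CC1=C(C(=O)Nc2ccc([N+](=O)[O-])cc2)C(c2ccc(Br)cc2)N=C(SCc2ccccc2Cl)N1` differs from compound 3 by chloro in place of hydrogen on an aromatic carbon. Among the measured compounds shown here, no measured step adds a chloro where hydrogen stood; the only single step, a number 1 percentage points lower from compound 1 to compound 2 (within the scatter), moves a chloro between positions on that same benzyl and stays within the scatter. With nothing pointing either way, compound 4 is expected to show a step of a number 0.1 percentage points lower from compound 3 to compound 4 (within the scatter), which is none beyond the scatter. Compound 4 is therefore estimated at 21% in this assay, between 8% and 34%.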

Compound 4, a percentage reported as inhibition, in the whole organism at one dose (the size of the read-out at that dose, not a potency): 6.7%
For compound 4 the middle estimate is 14.3 percentage points above the measured one, and the stated range ends above it.
By their numbers in this assay, from the lowest: compounds 4, 2, 1 and 3 (each within the scatter of the next, the first and the last beyond it).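

In this assay the change from benzyl to 2-chlorobenzyl gives a number 14.4 percentage points lower from compound 3 to compound 4 (beyond the scatter) and is the first step among these compounds to go beyond the scatter. It shows that, on the core of compound 3, a chloro in place of hydrogen on this aromatic carbon, ortho to a large group, does change the read-out, which the earlier step moving a chloro around the benzyl could not show. Nothing measured here bears on why the number falls. On these data alone, whether a methyl or a methoxy group on that same carbon gives a like step stays open, as does whether 3-chlorobenzyl does so on the core of compound 3.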